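The compounds below may be only part of what the source reports. "The series", "measured", "known", "first", "only" and "open" are said of these compounds alone.

Working notes on the series. Compound 3 `O=c1cc(N2CCN(CC3CCC(OS(=O)(=O)c4ccccc4)CC3)CC2)sc2c([N+](=O)[O-])cc(C(F)(F)F)cc12` is the point of departure. In an ADME assay on Vero cells (Chlorocebus sabaeus) for cytotoxicity, read by MTT assay, with a stated time of 48 h (a higher number here means a weaker inhibitor, a lower number a stronger inhibitor), compound 3 gives > 64 ug/mL, which is a limit of the assay and not a number. Compound 1 `O=C(OC1CCC(CN2CCN(c3cc(=O)c4cc(C(F)(F)F)cc([N+](=O)[O-])c4s3)CC2)CC1)C1CCC1` in this assay gives > 64 ug/mL, again a limit rather than a number. Compound 2 `O=C(OC1CCC(CN2CCN(c3cc(=O)c4cc(C(F)(F)F)cc([N+](=O)[O-])c4s3)CC2)CC1)c1ccco1` in this assay gives > 64 ug/mL, also a limit. Hence none of the measured changes can be sized: a step that the two limits leave unreadable from compound 1 to compound 2, a step that the two limits leave unreadable from compound 1 to compound 3 and a step that the two limits leave unreadable from compound 2 to compound 3 are all unreadable, since every value rests on (the limit of > 64 ug/mL in this assay, at which 3 of the 3 values shown sit).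

Compound 4 `O=C(NC1CCC(CN2CCN(c3cc(=O)c4cc(C(F)(F)F)cc([N+](=O)[O-])c4s3)CC2)CC1)c1ccccc1` differs from compound 3 in one place: benzamido in place of (phenylsulfonyl)oxy on a saturated ring carbon. Among the compounds with values here, no measured step bears on this change in a readable way, so the only guide is that every analogue so far sits at the same limit. For compound 4 the expected step of a number no higher from compound 3 to compound 4 (the limit leaves the size open) is therefore none beyond the scatter, with the most likely outcome a further limit. The estimate for compound 4 in this assay is 64 ug/mL, within a range from 32 ug/mL to 128 ug/mL.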

Compound 4, half-maximal inhibitory concentration: 44.3 ug/mL
Beside the measured number, compound 4's estimate is 1.4-fold (0.16 log units) above it, and the stated range covers the measured number.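

Within the data shown here, on the saturated ring carbon, benzamido gives the first reading in this assay that is a number and not a limit, so this position can now yield a value. The change to benzamido gives an at least 1.4-fold lower number from compound 3 to compound 4 (0.15 log units; that floor lies within the scatter), an at least 1.4-fold lower number from compound 2 to compound 4 (0.15 log units; that floor lies within the scatter) and an at least 1.4-fold lower number from compound 1 to compound 4 (0.15 log units; that floor lies within the scatter), so none of these floors establishes a change beyond the scatter. The full size of each step stays unreadable because the other end of each is a limit: the limit of > 64 ug/mL in this assay, at which 3 of the 4 values shown sit.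

On these data alone, whether the numerical reading goes with the amide nitrogen or with the benzoyl group remains open. As far as these compounds go, how a free amine, a carboxylic acid or a sulfonamide on this ring carbon would read in this assay also remains open.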